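Removing the bromo group from compound 1

This account rests on a few compounds, and the source may have more. Where it says the series, first, only, none or still open, it means among the compounds named here.

Within the data shown here, the three measured members share one core and differ at its aromatic ring and at the substituent on the saturated ring. Compound 1 `CCO[C@H]1C[C@@H](c2coc3ccc(Br)cc3c2=O)N(c2ccccc2)O1` carries a bromo group on the aromatic ring. In a functional assay on Caco-2 cells (Homo sapiens) for inhibition, read by sulforhodamine B assay, with a stated time of 48 h (a lower number here means a stronger inhibitor, a higher number a weaker inhibitor), compound 1 reaches only a limit of the assay, > 60000 nM. Compound 3 `CCO[C@H]1C[C@@H](c2coc3cc(Cl)c(Cl)cc3c2=O)N(c2ccccc2)O1` likewise returns only a limit in this assay, > 60000 nM. Among the measured compounds shown here, compound 2 `N#C[C@H]1C[C@@H](c2coc3ccc(Cl)cc3c2=O)N(c2ccccc2)O1` is the sole member that gives a number in this assay, 39000 nM. Two of the three values therefore sit at the limit of > 60000 nM in this assay, at which 2 of the 3 values shown sit, and compound 1 is one of them; its value cannot be placed in order against compound 2, whose number lies close to that limit.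

Compound 4 `CCO[C@H]1C[C@@H](c2coc3ccccc3c2=O)N(c2ccccc2)O1` differs from compound 1 by hydrogen in place of bromo on an aromatic carbon. For the measured compounds named here, no step between two measured compounds that differ in one place is available to calibrate this change. In this assay the expectation is for no shift beyond the usual scatter in either direction, so the step of a number no higher from compound 1 to compound 4 (the limit leaves the size open) is expected to be essentially flat. Compound 4 is accordingly estimated at 60000 nM, within a range from 20000 nM to 200000 nM, with a real chance that only a limit is reported again.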

Compound 4, half-maximal inhibitory concentration: > 60000 nM
Compound 4: no number, only a limit (the forecaster's own chance of this, stated with the estimate: 65%); the middle value lies on the limit itself.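

Among these compounds, compound 1 and compound 4 each return only a limit in this assay, so no step between them can be read. The compounds shown leave open whether hydrogen in place of bromo on an aromatic carbon changes inhibition at all, as most of the series rests on one limit: the limit of > 60000 nM in this assay, at which 3 of the 4 values shown sit.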